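Working notes: a new aryl group on compound 3

The source may report more compounds than this note shows. Statements on the series, on what has been measured and on what is new or still open speak of the compounds shown alone.

Values in a functional assay on MCF7 cells (Homo sapiens) for cytotoxicity, read by MTT assay, with a stated time of 72 h; on this read-out higher numbers stand for weaker inhibition and lower numbers for stronger inhibition:
- compound 1 `O=C(N/N=C/c1ccc(F)cc1Cl)Nc1cc2c(Nc3ccc(F)c(Cl)c3)ncnc2cc1O[C@H]1CCOC1`: 32200 nM
- compound 2 `COc1cc2ncnc(Nc3ccc(F)c(Cl)c3)c2cc1NC(=O)N/N=C/c1cccc(Br)c1`: 27100 nM
- compound 3 `COc1cc2ncnc(Nc3ccc(F)c(Cl)c3)c2cc1NC(=O)N/N=C/c1ccc(F)cc1Cl`: "not active" (no number reported)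

Compound 3 has no single number to stand on, as the entry for compound 3 reads "not active" (no number reported). Among the compounds with values here, compound 1 at 32200 nM and compound 2 at 27100 nM lie within the scatter of each other, and these are the only two numbers.

Compound 4 `COc1cc2ncnc(Nc3ccc(F)c(Cl)c3)c2cc1NC(=O)N/N=C/c1cc(Br)c(O)c(Br)c1` has not yet been measured. The change 3,5-dibromo-4-hydroxyphenyl in place of 2-chloro-4-fluorophenyl on a carbon with a double bond to nitrogen puts 3,5-dibromo-4-hydroxyphenyl in place of 2-chloro-4-fluorophenyl on a carbon with a double bond to nitrogen.

Within the data shown here, no measured step shows what a change at this place does, and without a number for compound 3 no size can be put on a step from it. The expected direction in this assay is towards a measurable value, with compound 4 expected to differ by no more than the scatter from compound 2 at 27100 nM. For compound 4 the estimated value is 22000 nM, with an expected range of 8000 nM to 50000 nM.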

Compound 4, half-maximal inhibitory concentration: 30200 nM
Compound 4: the middle estimate sits 1.4-fold (0.14 log units) below what was measured; the measured number falls inside the stated range.
By their numbers in this assay, from the lowest: compounds 2, 4 and 1 (each within the scatter of the next).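

In this assay compound 4 gives 30200 nM with 3,5-dibromo-4-hydroxyphenyl on a carbon with a double bond to nitrogen, whereas compound 3 with 2-chloro-4-fluorophenyl at the same place is recorded only as "not active". Between 3-bromophenyl and 3,5-dibromo-4-hydroxyphenyl the reading is a 1.1-fold higher number from compound 2 to compound 4 (0.05 log units; within the scatter) and so these two aryl groups cannot be told apart in this read-out. Nothing on hand bears on why compound 4 has a number and compound 3 has none.

The size of the step from compound 3 to compound 4 cannot be read without a number for compound 3. Open, from the compounds shown here alone, is whether a carboxylic acid or a dimethylamino group on the aryl ring at this place gives a value beyond the scatter from compound 2.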